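The source may report more compounds than this note shows. Statements on the series, on what has been measured and on what is new or still open speak of the compounds shown alone.

Working notes on the series

Two compounds have numbers in an assay on HEK293 cells for inhibition of Voltage-dependent T-type calcium channel subunit alpha-1G (Homo sapiens), read by fluorescence, tested at 10 uM; on this read-out higher numbers stand for more inhibition at the one concentration tested (going by the name of the read-out) and lower numbers for less inhibition. Compound 1 `CCCc1nc(-c2ccccc2)c(CNCCCN2CCN(c3ccccc3F)CC2)o1` gives 54.4% in this assay. Compound 2 `CCCc1nc(-c2ccccc2)c(CNCCN2CCN(c3ccccc3)CC2)o1` gives 54.3% in this assay. Compound 1 is nominally the higher of the two numbers, but the gap to compound 2 lies within the scatter of repeated measurements, so the two numbers cannot be told apart and neither compound stands out. For the measured compounds named here, no pair of measured compounds differs in a single place, so no measured step is available to guide the next one.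

The compound still to be measured is compound 3 `CCCc1nc(-c2ccccc2)c(CNCCCN2CCN(c3cccc(C(F)(F)F)c3)CC2)o1`. It differs from compound 1 in one place: 3-(trifluoromethyl)phenyl in place of 2-fluorophenyl on an amine nitrogen in a ring. Going by the values given here, there is nothing in the two numbers so far to suggest that this change moves the read-out strongly in either direction. The step of a number 0.6 percentage points higher from compound 1 to compound 3 (within the scatter) is expected to stay within the scatter, with a wide margin of uncertainty given the thin data. Compound 3 is therefore estimated at 55% in this assay, with an expected range from 33% to 77%.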

Compound 3, a percentage reported as inhibition, at one concentration (the size of the read-out at that concentration, not a potency): 51.6%
Compound 3: the middle estimate sits 3.4 percentage points above what was measured, within the range that was stated.
By their numbers in this assay, from the lowest: compounds 3, 2 and 1 (each within the scatter of the next).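

For the compounds shown here, this is the first step that changes a single place: putting 3-(trifluoromethyl)phenyl in place of 2-fluorophenyl on an amine nitrogen in a ring gives a number 2.8 percentage points lower from compound 1 to compound 3 (within the scatter) in this assay. At this position, then, the read-out does not separate the two aryl groups, even though the entering group has 10 heavy atoms against 7 and carries 3 fluorine atoms against 1. No independent measurement is available to explain this outcome.

Going by these compounds alone, the two groups differ both in the substituent and in its numbered place on the phenyl ring, so this single step cannot separate those two changes, and a read-out at one concentration gives no potency for either compound. Still open, from the compounds shown here alone, is whether a more different group at this position, such as a pyridine ring in place of the phenyl ring or a phenyl ring bearing a carboxylic acid or a primary amine, would give a step beyond the scatter in this assay.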